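Swapping propylsulfanyl for pentafluoropropoxy on a weak compound

The source may report more compounds than this note shows. Statements on the series, on what has been measured and on what is new or still open speak of the compounds shown alone.

In a functional assay on BXPC-3 cells (Homo sapiens) for antiproliferative activity, read by sulforhodamine B assay, with a stated time of 72 h (on this read-out higher numbers stand for weaker inhibition and lower numbers for stronger inhibition), compound 1 `C=CCOC(=O)C1=C2C(=NC1=O)c1cccc3c(SCCC)ccc2c13` gives 12900 nM, while compound 2 `CCCSC(=O)COC(=O)C1=C2C(=NC1=O)c1cccc3c(SCCC)ccc2c13` gives 56300 nM. Compound 2 therefore holds the higher of the two numbers and is the weaker inhibitor of this pair. Compound 3 `CCCSc1ccc2c3c(cccc13)C1=NC(=O)C(C(=O)OCC(=O)OCC(F)(F)C(F)(F)F)=C12` keeps the shared core and differs from compound 2 in one place: 2,2,3,3,3-pentafluoropropoxy in place of propylsulfanyl on a carbonyl carbon. For the measured compounds named here, only one measured step bears on this change: a 4.4-fold higher number from compound 1 to compound 2 (0.64 log units; beyond the scatter). That modest step brought in the propylsulfanyl group that now leaves. Going by the values given here, no measured compound carries 2,2,3,3,3-pentafluoropropoxy, so the guidance is thin and the range must stay wide. The value of compound 1, 12900 nM, shows that this core can reach lower numbers, so a modest drop is expected rather than a further rise. Among the compounds with values here, the estimated change is a 2.3-fold lower number from compound 2 to compound 3 (0.35 log units; beyond the scatter), similar in size to the one measured step or smaller. Compound 3 is expected at about 25000 nM, with an estimated range from 8000 nM to 70000 nM.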

Compound 3, half-maximal inhibitory concentration: 54100 nM
The estimate for compound 3 lay 2.2-fold (0.34 log units) below the measured number, and the stated range covers the measured number.
By their numbers in this assay, from the lowest: compound 1; then compounds 3 and 2 (each within the scatter of the next).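

In this assay, the group on this carbonyl carbon can be exchanged with no readable effect, a 1.0-fold lower number from compound 2 to compound 3 (0.02 log units; within the scatter). Propylsulfanyl and 2,2,3,3,3-pentafluoropropoxy thus cannot be told apart here, even though they differ in their atoms and the entering group has more heavy atoms. Compound 1 keeps the lowest number of the three, and the second carbonyl-bearing group again moves away from it, a 4.2-fold higher number from compound 1 to compound 3 (0.62 log units; beyond the scatter), in the same direction as a 4.4-fold higher number from compound 1 to compound 2 (0.64 log units; beyond the scatter), so in both cases replacing vinyl gives weaker inhibition. No measurements are available to explain either the lack of change or the shift away from compound 1.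

The compounds shown leave open whether a different group on this carbonyl carbon, such as an amine or a carboxylic acid, would separate from the two tested here, and whether any replacement for vinyl, such as a phenyl ring or a longer chain, could fall below the number of compound 1. As far as these compounds go, the propylsulfanyl group on the shared core is also the same in all three compounds, so its contribution remains untested by this set.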